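Replacing 4-chloro-2-fluorophenyl with 5-chloropyridin-2-yl

A few compounds are considered here, and "the series" means these few. Any claim that something is new, unique, unknown or untested is made for them only; others in the source may bear on it.

Compound 1 `CN1C[C@H](C(=O)Nc2cccc(F)c2)[C@@H](c2ccc(/C=C/C(=O)Nc3ccccc3N)cc2)C1` - 6 mL/min/kg
Compound 2 `CN1C[C@H](C(=O)Nc2ccccc2F)[C@@H](c2ccc(/C=C/C(=O)Nc3ccccc3N)cc2)C1` - 10 mL/min/kg
Compound 3 `CN1C[C@H](C(=O)Nc2ccc(Cl)cc2F)[C@@H](c2ccc(/C=C/C(=O)Nc3ccccc3N)cc2)C1` - 11 mL/min/kg

All three compounds were measured in an in vitro ADME assay on microsomes from liver (Homo sapiens) for pharmacokinetics, read by LC-MS, with a stated time of 10 min, tested at 1 uM; on this read-out higher numbers stand for fast clearance and lower numbers for slow clearance. Compound 3 gives 11 mL/min/kg and stands within the scatter of both other compounds, with a 1.8-fold higher number from compound 1 to compound 3 (0.26 log units; within the scatter) and a 1.1-fold higher number from compound 2 to compound 3 (0.04 log units; within the scatter).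

The next compound, compound 4 `CN1C[C@H](C(=O)Nc2ccc(Cl)cn2)[C@@H](c2ccc(/C=C/C(=O)Nc3ccccc3N)cc2)C1`, carries 5-chloropyridin-2-yl in place of 4-chloro-2-fluorophenyl on an amide-type nitrogen.

The group on this nitrogen already differs among the measured compounds. The exchange of one fluorophenyl for the other gave a 1.7-fold higher number from compound 1 to compound 2 (0.22 log units; within the scatter), and the two steps to compound 3 were also within the scatter. For the measured compounds named here, none of the three measured compounds, however, carries an aromatic ring with a hetero atom at this place, so no measured step covers the exchange directly. With that caveat, the small steps seen so far in this assay give no reason to expect a change beyond the scatter, in either direction.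

The expected step is a 1.2-fold lower number from compound 3 to compound 4 (0.09 log units; within the scatter), an estimate that stays within the scatter. For compound 4 the estimated clearance is 9 mL/min/kg, with an expected range of 4 mL/min/kg to 20 mL/min/kg.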

Compound 4, clearance: 13 mL/min/kg
Estimate against measurement, compound 4: 1.4-fold (0.16 log units) below; measured number inside the range.
By their numbers in this assay, from the lowest: compounds 1, 2, 3 and 4 (each within the scatter of the next, the first and the last beyond it).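

In this assay the amide-type nitrogen now carries, for the first time among these compounds, an aromatic ring with a hetero atom, and this exchange gives a 1.2-fold higher number from compound 3 to compound 4 (0.07 log units; within the scatter) and a 1.3-fold higher number from compound 2 to compound 4 (0.11 log units; within the scatter), so 5-chloropyridin-2-yl, with its one hydrogen-bond acceptor, is not separated from 4-chloro-2-fluorophenyl or 2-fluorophenyl at this position. For the compounds shown here, the comparison with 3-fluorophenyl is different, giving a 2.2-fold higher number from compound 1 to compound 4 (0.34 log units; beyond the scatter), the first modest step at this position that lies beyond the scatter, which shows that the group on this nitrogen can move the read-out past that limit, though only in this one pair. Nothing shown explains any of these steps.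

The compounds shown leave open what the ring nitrogen and the fluoro group each contribute, since the exchange from compound 3 to compound 4 changes both at once and a plain pyridin-2-yl group does not stand among them. They also leave open how this position would respond to a group of another kind on the ring, such as an amine or a carboxylic acid, or to a longer chain in place of the aromatic ring.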